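Terminal alkyne at the chain end: cytotoxicity outlook

The source may hold more compounds than are shown below. What is called first, only, known or untested is meant among the compounds shown, and "the series" means these compounds.

The series shares one core and varies the chain attached to an aromatic carbon. Compound 1 is `CCCCCc1cc2cn([C@H]3C[C@H](O)[C@@H](CO)O3)c(=O)nc2o1`. In a functional assay on HEL cells (Homo sapiens) for cytotoxicity, read by microscopy (a lower number here means that less compound is tolerated, a higher number that more compound is tolerated), compound 1 reaches only a limit, > 50000 nM. Compound 2 is `C=CCCCCc1cc2cn([C@H]3C[C@H](O)[C@@H](CO)O3)c(=O)nc2o1`. In this assay compound 2 likewise gives only a limit, > 200000 nM. The step that the two limits leave unreadable from compound 1 to compound 2 therefore cannot be sized, since one value sits at the limit of > 50000 nM in this assay, at which 1 of the 2 values shown sits, and the other at the limit of > 200000 nM in this assay, at which 1 of the 2 values shown sits. Compound 3 is `C#CCCCc1cc2cn([C@H]3C[C@H](O)[C@@H](CO)O3)c(=O)nc2o1`. Its change from compound 2 is ethynyl in place of allyl on a saturated chain carbon, three bonds along the chain from an aromatic carbon. Going by the values given here, only the step from compound 1 to compound 2 bears on this change, and it is unreadable, so no direction can be drawn from it; both chain variants seen so far are tolerated up to the limit in this assay. The expectation for compound 3 in this assay is accordingly a value at or near the limit, estimated as 200000 nM with a range from 50000 nM to 800000 nM. The estimated step of a number no higher from compound 2 to compound 3 (the limit leaves the size open) is expected to stay within the scatter.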

Compound 3, minimum cytotoxic concentration: > 200000 nM
Compound 3 gave a limit, no number; the forecaster's own chance of this, stated with the estimate: 85%; the middle value lies on the limit itself.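

In this assay compound 3 gives > 200000 nM, a limit and not a number, so its steps from compound 1 and compound 2 cannot be read. The compounds shown leave open whether any of these chain changes alters tolerated concentration in this assay.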